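A few compounds are considered here, and "the series" means these few. Any claim that something is new, unique, unknown or untested is made for them only; others in the source may bear on it.

Measured in an ADME assay on MT4 cells (Homo sapiens) for cytotoxicity, read by MTT assay; a higher number here means that more compound is tolerated, a lower number that less compound is tolerated:
Compound 1 `Cc1c(Cc2c(F)cccc2F)nc(SCC(=O)c2ccccc2)[nH]c1=O`: 65000 nM
Compound 2 `Cc1c(Cc2c(F)cccc2F)nc(SCC(=O)c2ccc(F)cc2)[nH]c1=O`: > 62000 nM

Compound 2 stands only at a limit of the assay, > 62000 nM, and not at a number. Among the measured compounds shown here, the only exact number is that of compound 1, 65000 nM. Compound 3 `COc1ccc(C(=O)CSc2nc(Cc3c(F)cccc3F)c(C)c(=O)[nH]2)cc1` carries methoxy in place of fluoro on an aromatic carbon, para to a large group (methoxy in place of fluoro on an aromatic carbon). For the measured compounds named here, only one measured step bears on this change, a step that the limit leaves unreadable from compound 1 to compound 2, and it gives no size to carry over. No step beyond the scatter is therefore expected in this assay, in either direction. The expected step is an at least 1.1-fold lower number from compound 2 to compound 3 (0.05 log units; that floor lies within the scatter). Compound 3 is estimated at 55000 nM, with an expected range of 25000 nM to 120000 nM.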

Compound 3, half-maximal cytotoxic concentration: > 60000 nM
Compound 3 gave a limit, no number; the forecaster's own chance of this, stated with the estimate: 50%; at least 1.0-fold (0.03 log units) between middle value and limit.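

In this assay compound 3 gave only a limit (> 60000 nM). Compound 2 also stands at a limit (> 62000 nM). Among the compounds shown here, no step can therefore be read among compound 1, compound 2 and compound 3. The compounds shown leave open whether fluoro or methoxy at this place changes the tolerated concentration at all, and by how much.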